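Removing the Fluoro Substituent: What to Expect for Compound 4

The compounds below may be only part of what the source reports. "The series", "measured", "known", "first", "only" and "open" are said of these compounds alone.

Measured so far:
compound 1 `CCC(C(=O)N1CCN(c2ccccc2C(F)(F)F)CC1)N1C(=O)CCC1=O` gives 0%
compound 2 `CC(C(=O)N1CCN(c2ccc(F)cc2)CC1)N1C(=O)CCC1=O` gives 25%
compound 3 `CCC(C(=O)N1CCN(c2ccccc2Cl)CC1)N1C(=O)CCC1=O` gives 50%

In a functional assay on the whole organism (strain Swiss) with Mus musculus as the target, in the maximal electroshock model, with a stated time of 1 h, at a dose of 300 mg/kg by the intraperitoneal route (on this read-out higher numbers stand for a stronger effect at the one dose given and lower numbers for a weaker effect), compound 2 stands second highest of the three numbers shown, beyond the scatter from both compound 1 and compound 3. Compound 4 `CC(C(=O)N1CCN(c2ccccc2)CC1)N1C(=O)CCC1=O` differs from compound 2 by hydrogen in place of fluoro on an aromatic carbon. For the measured compounds named here, no measured step touches this position; the only one-place step available, a number 50 percentage points higher from compound 1 to compound 3 (beyond the scatter), concerns a different group at a different place and therefore offers no direct guide. With nothing bearing on the change, compound 4 is expected to move little, a number 5 percentage points lower from compound 2 to compound 4 (within the scatter), within the scatter. Compound 4 is estimated at 20%, with a range from 0% to 50%.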

Compound 4, a percentage reported as activity, at one dose (the size of the read-out at that dose, not a potency): 50%
For compound 4 the middle estimate is 30 percentage points below the measured one; the range from low to high includes it.
By their numbers in this assay, from the lowest: compound 1; then compound 2; then compounds 3 and 4 (each within the scatter of the next).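

In this assay hydrogen in place of fluoro gives a number 25 percentage points higher from compound 2 to compound 4 (beyond the scatter) and so shows that this aromatic carbon, para to a large group, responds to a change of a single atom. The fluoro is not required for the effect at this one dose. Nothing available explains the step. From the compounds shown here alone, what remains open is how a methoxy group or an amine at this place would read, and whether the same change would give a similar step in the other compounds.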